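Series notes: substituent on the ring nitrogen and permeability

The compounds below may be only part of what the source reports. "The series", "measured", "known", "first", "only" and "open" are said of these compounds alone.

Compound 1 `CCCC[C@H](NC(=O)[C@H](CCCCN)NC(=O)[C@H](CCCNC(=N)N)NC(=O)c1ccc(/C=C2\SC(=O)N(c3ccc(C)cc3)C2=O)cc1)C(N)=O` carries 4-methylphenyl on the amide-type nitrogen in the ring; in an ADME assay for permeability, using PAMPA (a higher number here means that the compound crosses the layer faster, a lower number that the compound crosses the layer more slowly), compound 1 gives 0.66 10^-6 cm/s. Among the measured compounds shown here, compound 3 `CCCC[C@H](NC(=O)[C@H](CCCCN)NC(=O)[C@H](CCCNC(=N)N)NC(=O)c1ccc(/C=C2\SC(=O)N(Cc3ccc(Cl)cc3)C2=O)cc1)C(N)=O` carries 4-chlorobenzyl at the same nitrogen, and in this assay compound 3 gives 1.11 10^-6 cm/s, the higher of the two numbers so far, although the step of a 1.7-fold higher number from compound 1 to compound 3 (0.23 log units; within the scatter). Compound 2 `CCCC[C@H](NC(=O)[C@H](CCCCN)NC(=O)[C@H](CCCNC(=N)N)NC(=O)c1ccc(/C=C/C(N)=O)cc1)C(N)=O` is a separate case: in this assay compound 2 is reported as "impermeable" (no number reported), with no number given.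

For the measured compounds named here, compound 4 `CCCC[C@H](NC(=O)[C@H](CCCCN)NC(=O)[C@H](CCCNC(=N)N)NC(=O)c1ccc(/C=C2\SC(=O)N(CCOC(C)=O)C2=O)cc1)C(N)=O` is the next candidate. acetoxymethyl in place of 4-chlorophenyl on a saturated chain carbon bound to an amide-type nitrogen in a ring The only measured step, a 1.7-fold higher number from compound 1 to compound 3 (0.23 log units; within the scatter), swaps one group containing a six-membered aromatic ring of carbon only for another and so does not bear directly on this change, where that ring leaves and no ring enters. Going by the values given here, compound 2, the one compound without such a ring, gives "impermeable" (no number reported). A downward step is therefore expected for compound 4, a 2.2-fold lower number from compound 3 to compound 4 (0.35 log units; beyond the scatter), with a real chance that only a limit is returned. Compound 4 is estimated at 0.5 10^-6 cm/s, between 0.2 10^-6 cm/s and 1.2 10^-6 cm/s.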

Compound 4, apparent permeability: "impermeable" (no number reported)
No number was reported for compound 4, and the estimate cannot be compared.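

In this assay, among the compounds shown here, compound 4 gives "impermeable" (no number reported) and so no step from compound 3 to compound 4 can be read. No data shown bear on this result. The compounds shown leave open how far 2-acetoxyethyl lies numerically from 4-chlorobenzyl.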